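Cyclobutyl Ring Redesign Toward a Stronger Kinase Inhibitor

A few compounds are considered here, and "the series" means these few. Any claim that something is new, unique, unknown or untested is made for them only; others in the source may bear on it.

Compound 1 `N#Cc1cnc(NCc2cnccc2C(F)(F)F)cc1NC[C@H]1C[C@H](O)C1` stands with the higher of the two numbers recorded so far in an assay on isolated protein for inhibition of protein kinase C theta type (Homo sapiens), read by TR-FRET, with a stated time of 2 h (a lower number here means a stronger inhibitor, a higher number a weaker inhibitor), giving 700 nM. Compound 2 `CC1(C)C[C@H](Nc2cc(NCc3cnccc3C(F)(F)F)ncc2C#N)CC(C)(C)[C@H]1O` gives 20 nM in this assay, a gap beyond the usual scatter. Compound 3 `CC1(C)[C@@H](C(N)=O)C[C@H]1Nc1cc(NCc2cnccc2C(F)(F)F)ncc1C#N` differs from compound 1 by 3-carbamoyl-2,2-dimethylcyclobutyl in place of (3-hydroxycyclobutyl)methyl on a nitrogen on an aromatic ring. Among the compounds with values here, no measured pair shows this change, so the expectation rests on compound 2 reaching 20 nM with a ring set directly on the same nitrogen; the step is expected to run towards a lower number, of size a 7.0-fold lower number from compound 1 to compound 3 (0.85 log units; beyond the scatter). Compound 3 is estimated at 100 nM, within 30 nM to 400 nM.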

Compound 3, half-maximal inhibitory concentration: 1.4 nM
The estimate for compound 3 lay 71-fold (1.85 log units) above the measured number, and the stated range ends above it.
By their numbers in this assay, from the lowest: compound 3; then compound 2; then compound 1.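

In this assay, the step at this nitrogen on an aromatic ring is large, with a 500-fold lower number from compound 1 to compound 3 (2.70 log units; beyond the scatter) on exchanging (3-hydroxycyclobutyl)methyl for 3-carbamoyl-2,2-dimethylcyclobutyl. The position therefore accepts the bigger substituent and can carry a far stronger inhibitor on the same core. Nothing measured here accounts for the step. The exchange alters the link to the nitrogen, the two ring methyl groups and the hydroxyl-to-carbamoyl change together, so their separate shares remain unresolved. Going by these compounds, whether a carboxylic acid or an amine in place of the carbamoyl would keep this strength also stays open.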